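Urea series: swapping tert-butyl for trifluoromethyl on the aryl ring

A few compounds are considered here, and "the series" means these few. Any claim that something is new, unique, unknown or untested is made for them only; others in the source may bear on it.

Measured compounds in an ADME assay on the whole organism with Oryza sativa as the target, tested at 10 uM; a lower number here means a stronger effect, a higher number a weaker effect of the compound at the concentration tested:
- compound 1, `CC(C)c1cccc(NC(=O)N[C@@H](C)c2ccccc2)c1`: 86%
- compound 2, `C[C@@H](NC(=O)Nc1ccc(C(C)(C)C)cc1)c1ccccc1`: 53%
- compound 3, `C[C@H](NC(=O)Nc1ccc(C(C)(C)C)cc1)c1ccccc1`: 64%

Compound 2 stands lowest of the three numbers in this assay. Its nearest neighbour is compound 3, and the step is a number 11 percentage points higher from compound 2 to compound 3 (beyond the scatter), which rests on (the fact that compounds 2 and 3 differ only in the configuration as drawn). Compound 1 lies furthest away, and a comparison of the two values shows compound 1 well above compound 2.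

The next compound, compound 4, is `C[C@@H](NC(=O)Nc1ccc(C(F)(F)F)cc1)c1ccccc1`. Relative to compound 2 the change is trifluoromethyl in place of tert-butyl on an aromatic carbon; the trifluoromethyl sits on an aromatic carbon of the six-membered aromatic ring of carbon only, para to a large group.

Within the data shown here, none of the measured steps touches this substituent: the only step between measured compounds, from compound 2 to compound 3, concerns configuration alone, and the gap between compound 1 and compound 2 involves a different substituent at a different position of the shared core. Among the measured compounds shown here, there is therefore no measured precedent for the exchange of tert-butyl for trifluoromethyl, and no direction can be read from the numbers. The expectation for compound 4 in this assay is accordingly a step of a number 2 percentage points higher from compound 2 to compound 4 (within the scatter), that is, none beyond the scatter. Compound 4 is estimated at 55%, with a range from 35% to 78%.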

Compound 4, a percentage reported as activity, at one concentration (the size of the read-out at that concentration, not a potency): 82%
Compound 4: middle estimate off by 27 percentage points, on the low side; measured number outside the range, above it.
By their numbers in this assay, from the lowest: compound 2; then compound 3; then compounds 4 and 1 (each within the scatter of the next).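

At this position, on an aromatic carbon para to a large group, the substituent matters in this assay: with the configuration as drawn held constant, trifluoromethyl in place of tert-butyl gives a clear change (a number 29 percentage points higher from compound 2 to compound 4 (beyond the scatter)) and so weakens the effect of the compound at the concentration tested. This substituent exchange moves the read-out further than inverting the stereocentre does (a number 11 percentage points higher from compound 2 to compound 3 (beyond the scatter)), even though the leaving and entering groups match in heavy-atom count and neither carries a ring or a hydrogen-bond donor or acceptor. Those counts therefore do not separate tert-butyl from trifluoromethyl here, and nothing available bears on the origin of the step.

Whether the step reflects something particular to trifluoromethyl or to tert-butyl remains open, since these are the only two groups shown at this place, and a nitrile, a methoxy group or a chlorine atom there would help separate the two readings. Also open, on these data alone, is whether the difference between the two configurations seen with tert-butyl persists when trifluoromethyl occupies this position.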